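Chalcone series: trichlorophenyl replacing nitrophenyl on the carbonyl

The compounds below may be only part of what the source reports. "The series", "measured", "known", "first", "only" and "open" are said of these compounds alone.

Measured so far:
compound 1 `O=C(/C=C/c1cccc(OCc2ccccc2)c1)c1ccc(Br)cc1`, 1000 nM in a functional assay on 2008 cells (Homo sapiens) for cytotoxicity, read by MTT assay, with a stated time of 68 h; a lower number here means a stronger inhibitor, a higher number a weaker inhibitor
compound 2 `O=C(/C=C/c1cccc(OCc2ccccc2)c1)c1ccc([N+](=O)[O-])cc1`, 49000 nM in this assay

Among the measured compounds shown here, compound 2 has the highest number of the two in this assay; the single step in the set, a 49-fold higher number from compound 1 to compound 2 (1.69 log units; beyond the scatter), separates it from compound 1. Compound 3 `O=C(/C=C/c1cccc(OCc2ccccc2)c1)c1ccc(Cl)c(Cl)c1Cl` is not yet measured. Its change from compound 2 is 2,3,4-trichlorophenyl in place of 4-nitrophenyl on a carbonyl carbon. For the measured compounds named here, the only bearing step is a 49-fold higher number from compound 1 to compound 2 (1.69 log units; beyond the scatter), where bromo gave the far lower number than nitro. Three chlorines on the entering ring sit closer to bromo than to nitro, so the number for compound 3 is expected to drop well beyond the scatter, a 33-fold lower number from compound 2 to compound 3 (1.51 log units; beyond the scatter), toward that of compound 1. The estimate for compound 3 is 1500 nM with range 400 nM to 8000 nM.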

Compound 3, half-maximal inhibitory concentration: 1500 nM
Compound 3: middle estimate and measured number agree at the digits printed; measured number inside the range.
By their numbers in this assay, from the lowest: compounds 1 and 3 (each within the scatter of the next); then compound 2.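

On a carbonyl carbon, a second replacement for 4-nitrophenyl in this assay gives a 33-fold lower number from compound 2 to compound 3 (1.51 log units; beyond the scatter), so the high number of compound 2 is not a general feature of changing this ring. With a 1.5-fold higher number from compound 1 to compound 3 (0.18 log units; within the scatter), 4-bromophenyl and 2,3,4-trichlorophenyl cannot be told apart here, and three chlorines do no more than one bromo. No evidence bears on why the numbers fall this way.

Still open, on these data alone, is whether an amine or a carboxylic acid on this ring would track with compound 2 or with compound 1. A single chlorine would show how much of compound 3's number needs all three chlorines.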